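Aryl variation on the shared core: compound 2 to compound 4

The compounds below may be only part of what the source reports. "The series", "measured", "known", "first", "only" and "open" are said of these compounds alone.

In a functional assay on SMMC-7721 cells (Homo sapiens) for inhibition, read by CCK-8 assay (a lower number here means a stronger inhibitor, a higher number a weaker inhibitor), compound 1 `Oc1ccccc1/C=N/c1nnc(SCc2nnc(-c3ccccc3Cl)o2)s1` gives 31800 nM, compound 2 `Oc1ccccc1/C=N/c1nnc(SCc2nnc(-c3ccc(Br)cc3)o2)s1` gives 18000 nM and compound 3 `Cc1ccccc1-c1nnc(CSc2nnc(/N=C/c3ccccc3O)s2)o1` gives 15500 nM. Compound 2 stands second highest of the three numbers, though within the scatter of both compound 3 and compound 1. Compound 4 `O=[N+]([O-])c1cccc(-c2nnc(CSc3nnc(/N=C/c4ccccc4O)s3)o2)c1` differs from compound 2 by 3-nitrophenyl in place of 4-bromophenyl on an aromatic carbon. For the measured compounds named here, the steps that bear on this change are a 1.8-fold lower number from compound 1 to compound 2 (0.25 log units; within the scatter) and a 1.2-fold lower number from compound 2 to compound 3 (0.06 log units; within the scatter), both exchanges of the phenyl substituent on the same aromatic carbon; only a 2.1-fold lower number from compound 1 to compound 3 (0.31 log units; beyond the scatter) reaches beyond the scatter. Exchanges of this group have so far moved this assay little, so no step beyond the scatter is expected for a 1.1-fold lower number from compound 2 to compound 4 (0.05 log units; within the scatter). Compound 4 is therefore estimated at 16000 nM, with a range of 6000 nM to 40000 nM.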

Compound 4, half-maximal inhibitory concentration: 15700 nM
For compound 4 the middle estimate is 1.0-fold (0.01 log units) above the measured one, within the range that was stated.
By their numbers in this assay, from the lowest: compounds 3, 4, 2 and 1 (each within the scatter of the next, the first and the last beyond it).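

In this assay, 3-nitrophenyl adds a nitrogen, two oxygens and hydrogen-bond acceptors absent from 4-bromophenyl, yet a 1.1-fold lower number from compound 2 to compound 4 (0.06 log units; within the scatter) and a 1.0-fold higher number from compound 3 to compound 4 (0.01 log units; within the scatter) both stay within the scatter. Only a 2.0-fold lower number from compound 1 to compound 4 (0.31 log units; beyond the scatter) goes beyond it, and that step is modest, so this position has so far tolerated a nitro-bearing phenyl as well as the halogen- and methyl-bearing ones. Nothing on hand accounts for this flat response. Still open, from the compounds shown here alone, is whether an amine or a carboxylic acid on this phenyl would shift the number beyond the scatter from compound 2.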